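The source may report more compounds than this note shows. Statements on the series, on what has been measured and on what is new or still open speak of the compounds shown alone.

The measured compounds in a physicochemical assay for solubility, read by nephelometry, measured as kinetic solubility, at pH 2.0; on this read-out higher numbers stand for higher solubility and lower numbers for lower solubility:
compound 1 `CCOC(=O)C1=C(C)N/C(=C/c2cc(C)n(-c3ccc(Br)cc3)c2C)C1=O` gives 2.1 ug/mL
compound 2 `CCOC(=O)C1=C(C)N/C(=C/c2cc(C)n(-c3ccc(N(C)C)cc3)c2C)C1=O` gives 12.5 ug/mL
compound 3 `CCOC(=O)C1=C(C)N/C(=C/c2cc(C)n(-c3ccc(SC(F)(F)F)cc3)c2C)C1=O` gives 1 ug/mL

Among these three, compound 2 gives the highest number: the step of a 6.0-fold higher number from compound 1 to compound 2 (0.77 log units; beyond the scatter) and the step of a 13-fold lower number from compound 2 to compound 3 (1.10 log units; beyond the scatter) both run beyond the scatter, and a 2.1-fold lower number from compound 1 to compound 3 (0.32 log units; beyond the scatter) as well. Compound 4 `CCOC(=O)C1=C(C)N/C(=C/c2cc(C)n(-c3cccnc3)c2C)C1=O` is not yet measured; it differs from compound 2 by pyridin-3-yl in place of 4-(dimethylamino)phenyl on an aromatic nitrogen. Neither measured step exchanges the whole aryl group for a pyridinyl, so they bear on it only loosely; both steps away from compound 2 show that changing this group can move the number by modest to large amounts. The number for compound 4 is therefore expected to fall below that of compound 2, a step of a 3.1-fold lower number from compound 2 to compound 4 (0.49 log units; beyond the scatter), with an estimate of 4 ug/mL in a range from 1.5 ug/mL to 12 ug/mL.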

Compound 4, solubility: > 50 ug/mL
Compound 4 gave a limit, no number; the forecaster's own chance of this, stated with the estimate: 5%; at least 12-fold (1.09 log units) between middle value and limit.
By their numbers in this assay, from the lowest: compound 3; then compound 1; then compound 2. At a limit, above all of these: compound 4.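

The earlier compounds shown here varied only a substituent on the phenyl group, whereas exchanging the whole aryl group on the aromatic nitrogen for pyridin-3-yl gives, in this assay, an at least 4.0-fold higher number from compound 2 to compound 4 (0.60 log units; beyond the scatter). Among these compounds, it also gives an at least 23-fold higher number from compound 1 to compound 4 (1.37 log units; beyond the scatter), so this position can carry the read-out past the highest of the earlier compounds. Compound 4 stands at a limit, and the true size of both steps stays unknown: the limit of > 50 ug/mL in this assay, at which 1 of the 4 values shown sits.

Still open, from the compounds shown here alone, is whether pyridin-2-yl or pyridin-4-yl on the same aromatic nitrogen would read like pyridin-3-yl. Also open, going by these compounds, is how a pyridin-3-yl bearing an amine or a carboxylic acid would read in this assay.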